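Methyl to Hydroxymethyl: An Expected Drop in Lipophilicity

This account rests on a few compounds, and the source may have more. Where it says the series, first, only, none or still open, it means among the compounds named here.

Compound 1 `NCc1csc(NC(=O)c2ccc(Cl)cc2)n1` gives 1.6 in a physicochemical assay for lipophilicity, read by HPLC, at pH 7.4; a lower number here means a more polar compound, a higher number a more lipophilic compound.
Compound 2 `NCc1csc(NC(=O)c2cc3ccccc3n2Cc2ccccc2)n1` gives 3 in this assay.
Compound 3 `Cc1csc(NC(=O)c2cc(C(C)(C)C)nn2Cc2ccccc2)n1` gives 4.7 in this assay.

Among these three, compound 3 stands highest: its number lies beyond the scatter above compound 2, and further still above compound 1. Compound 4 `CC(C)(C)c1cc(C(=O)Nc2nc(CO)cs2)n(Cc2ccccc2)n1` is the next compound to be measured. It differs from compound 3 in one place: hydroxy in place of hydrogen on a saturated chain carbon bound to an aromatic carbon. Among the compounds with values here, no pair of measured compounds differing in just one place is available to calibrate this change, so the size of the step must be judged without a direct precedent. The expectation is a clear drop in this assay, larger than the scatter, with the step from compound 3 to compound 4 estimated at a number 1.00 log units lower from compound 3 to compound 4 (beyond the scatter). Compound 4 is therefore expected to give about 3.7, most likely between 3.1 and 4.3.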

Compound 4, distribution coefficient: 3.4
For compound 4 the middle estimate is 0.30 log units above the measured one; low and high end bracket the measured number.
By their numbers in this assay, from the lowest: compound 1; then compound 2; then compound 4; then compound 3.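

Within the data shown here, this is the first pair here that differs in only one place, so the change now has a measured size. In this assay, going from methyl to hydroxymethyl gives a number 1.30 log units lower from compound 3 to compound 4 (beyond the scatter), a large step for hydroxy in place of hydrogen on a saturated chain carbon bound to an aromatic carbon. No measurement shown explains why the step has this size. The compounds shown leave open how a methoxymethyl group, a carboxylic acid or a longer hydroxyethyl chain would read in this assay at this place. They also leave open whether the same change keeps its size on a different core.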